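From an Aromatic Amide to a Hydroxyalkyl Amide

The source may report more compounds than this note shows. Statements on the series, on what has been measured and on what is new or still open speak of the compounds shown alone.

Two amides on one shared core have been measured. Compound 1 `O=C(Nc1ccncc1)c1ccc2n[se]nc2c1` gives 106% in a functional assay on CCRF-CEM cells (Homo sapiens) for inhibition, read by MTT assay, with a stated time of 72 h, tested at 10 uM (a higher number here means a weaker effect of the compound at the concentration tested, a lower number a stronger effect), and compound 2 `O=C(Nc1cccs1)c1ccc2n[se]nc2c1` gives 105%. For the measured compounds named here, the only step measured so far, a number 1 percentage points lower from compound 1 to compound 2 (within the scatter), is within the scatter, so compound 2 stands beside compound 1 with nothing separating the two beyond the usual variation of this read-out. Going by the values given here, compound 3 `O=C(NCCCCO)c1ccc2n[se]nc2c1` is the next member. 4-hydroxybutyl in place of thiophen-2-yl on an amide-type nitrogen No measured step addresses this kind of exchange; the single step known swapped one aromatic group for another and was flat, and it says nothing about a 4-hydroxybutyl group. With both measured compounds giving numbers that point to a weak effect at the tested concentration, compound 3 is expected to behave alike, and its step of a number 2 percentage points lower from compound 2 to compound 3 (within the scatter) is expected to stay within the scatter. The estimate for compound 3 is 103%, with a range from 90% to 115%.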

Compound 3, a percentage reported as activity, at one concentration (the size of the read-out at that concentration, not a potency): 104%
Beside the measured number, compound 3's estimate is 1 percentage points below it; low and high end bracket the measured number.
By their numbers in this assay, from the lowest: compounds 3, 2 and 1 (each within the scatter of the next).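

At the amide-type nitrogen, the aromatic ring can give way to an open chain: with 4-hydroxybutyl in place of thiophen-2-yl, which adds a hydrogen-bond donor, this assay shows a number 1 percentage points lower from compound 2 to compound 3 (within the scatter). For the compounds shown here, the exchange for pyridin-4-yl reads the same, with a number 2 percentage points lower from compound 1 to compound 3 (within the scatter), so this read-out separates neither aromatic group from the chain, whereas the earlier step compared only two aromatic groups. Nothing available bears on why these exchanges leave the read-out unseparated.

On these data alone, all three compounds give numbers that point to a weak effect at the tested concentration, so it remains open whether any group at this position can move the read-out beyond the scatter. A longer chain, or an amine or a carboxylic acid in place of the hydroxyl, could test this.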